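Isopropylcarbonyl in Place of Methyl on Sulfur

The compounds below may be only part of what the source reports. "The series", "measured", "known", "first", "only" and "open" are said of these compounds alone.

Three compounds share one core and differ only in the group carried on a sulfur at the end of a saturated chain. Compound 1 `O=C(OCc1ccccc1)SCCCCCCNC(=O)c1cc(-c2ccncc2)n[nH]1` carries a benzyloxycarbonyl there, and in a functional assay on A549 cells (Homo sapiens) for inhibition, read by MTT assay, with a stated time of 96 h (on this read-out lower numbers stand for stronger inhibition of growth and higher numbers for weaker inhibition of growth), compound 1 gives 13400 nM. Compound 2 `CC(=O)SCCCCCCNC(=O)c1cc(-c2ccncc2)n[nH]1` carries an acetyl, and in this assay compound 2 gives 18000 nM. Compound 3 `CSCCCCCCNC(=O)c1cc(-c2ccncc2)n[nH]1` carries only a methyl on the sulfur. For compound 3 this assay reports no number but a limit, > 50000 nM, so compound 3 stands at the limit of > 50000 nM in this assay, at which 1 of the 3 values shown sits, and its true value is not pinned down.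

Compound 4 `CC(C)C(=O)SCCCCCCNC(=O)c1cc(-c2ccncc2)n[nH]1` differs from compound 3 by isopropylcarbonyl in place of methyl on a sulfur. The two measured steps that bear on this change run in the opposite direction: an at least 3.7-fold higher number from compound 1 to compound 3 (0.57 log units; beyond the scatter) and an at least 2.7-fold higher number from compound 2 to compound 3 (0.44 log units; beyond the scatter). In both, stripping a carbonyl-bearing group from the sulfur down to a bare methyl raised the number beyond the scatter. Restoring such a group with an isopropylcarbonyl is therefore expected to lower the number for compound 4 in this assay by at least a modest step, an at least 2.7-fold lower number from compound 3 to compound 4 (0.44 log units; beyond the scatter). Since compound 2 with an acetyl on the sulfur gives 18000 nM, compound 4 is expected to land near that, at about 18000 nM, within a likely range from 8000 nM to 40000 nM.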

Compound 4, concentration for 50% growth inhibition: 16800 nM
Compound 4: middle estimate off by 1.1-fold (0.03 log units), on the high side; measured number inside the range.
By their numbers in this assay, from the lowest: compounds 1, 4 and 2 (each within the scatter of the next). At a limit, above all of these: compound 3.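

On the sulfur at the end of the saturated chain, placing isopropyl on the carbonyl carbon in place of the methyl of the acetyl gives a 1.1-fold lower number from compound 2 to compound 4 (0.03 log units; within the scatter), and placing it there in place of benzyloxy gives a 1.3-fold higher number from compound 1 to compound 4 (0.10 log units; within the scatter), so these three carbonyl-bearing groups cannot be told apart in this assay. The earlier compounds offered only two such groups; with a third, the contrast with the bare methyl also holds, at an at least 2.9-fold lower number from compound 3 to compound 4 (0.47 log units; beyond the scatter), and among these four compounds what matters is whether a carbonyl-bearing group is present, not which one. The size of that contrast remains open-ended, as compound 3 sits at a limit and not at a true number: the limit of > 50000 nM in this assay, at which 1 of the 4 values shown sits.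

Still open, from the compounds shown here alone, is whether the sulfur needs a carbonyl-bearing group at all: a free thiol, with only hydrogen on the sulfur, would test this, while a tert-butyl or a phenyl on the carbonyl carbon would show how far the flat response extends. Also open, going by these compounds, is how these results would change with a shorter or a longer saturated chain.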